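The compounds below may be only part of what the source reports. "The series", "measured", "known", "first", "only" and "open" are said of these compounds alone.

In a functional assay on K562 cells (Homo sapiens) for inhibition, read by trypan blue exclusion, with a stated time of 72 h (a lower number here means a stronger inhibitor, a higher number a weaker inhibitor), compound 1 `Cn1c(=O)c(S(=O)(=O)c2ccc(F)cc2)cc2cnc(Nc3ccc4cc[nH]c4c3)nc21` gives 10000 nM. Compound 2 `O=c1c(S(=O)(=O)c2ccc(F)cc2F)cc2cnc(Nc3ccc4[nH]ccc4c3)nc2n1C1CCCC1` gives 5000 nM, which lies within the scatter of compound 1, so this assay cannot separate the two. Compound 3 `Cn1c(=O)c(S(=O)(=O)c2ccc(F)cc2F)cc2cnc(Nc3ccncn3)nc21` gives 30000 nM, a higher number beyond the scatter, which marks it as a weaker inhibitor than compound 1. Compound 1 therefore stands level with compound 2, and both sit on the stronger side of compound 3.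

Compound 4 `Cn1c(=O)c(S(=O)(=O)c2ccc(F)cc2)cc2cnc(Nc3ccc4[nH]ccc4c3)nc21` has not yet been measured. It has the same atoms as compound 1, joined differently: 1H-indol-5-yl in place of 1H-indol-6-yl on a nitrogen on an aromatic ring. Put simply, 1H-indol-5-yl replaces 1H-indol-6-yl on a nitrogen on an aromatic ring.

Within the data shown here, no measured pair shows this change alone. Compound 2 also carries the 1H-indol-5-yl group and gives 5000 nM, but it differs from compound 1 in other places too, so it offers only a weak hint. In this assay, the estimated step, a 1.3-fold lower number from compound 1 to compound 4 (0.10 log units; within the scatter), is expected to stay within the scatter, with no clear change in either direction. Compound 4 is expected to give about 8000 nM, with an estimated range of 2500 nM to 25000 nM.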

Compound 4, half-maximal inhibitory concentration: 200 nM
Beside the measured number, compound 4's estimate is 40-fold (1.60 log units) above it, outside the stated range (below it).
By their numbers in this assay, from the lowest: compound 4; then compounds 2 and 1 (each within the scatter of the next); then compound 3.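

With every atom kept, putting 1H-indol-5-yl in place of 1H-indol-6-yl on a nitrogen on an aromatic ring gives a 50-fold lower number from compound 1 to compound 4 (1.70 log units; beyond the scatter) in this assay. The two groups match in heavy atoms, hydrogen-bond donors, hydrogen-bond acceptors and charge, so those counts do not separate them, yet this assay does, and for this pair the way the group is joined matters a great deal. No information on hand explains why this single change has so large an effect.

On these data alone, it remains open whether a 1H-indol-4-yl or 1H-indol-7-yl group, or a phenyl ring carrying a piperazine, on the same nitrogen would match compound 4 or fall back towards compound 1. As far as these compounds go, it is also open whether the 1H-indol-5-yl group keeps this advantage when the methyl on the shared core gives way to a larger group such as cyclopentyl, a question compound 2 cannot settle, as it differs from compound 4 in more than one place.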